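Fluoro for Methoxy Across Two Related Cores

The source may hold more compounds than are shown below. What is called first, only, known or untested is meant among the compounds shown, and "the series" means these compounds.

Compound 1 `COc1ccc(Nc2c(C(=O)C(F)(F)F)c(=O)oc3cc(OC)ccc23)cc1` and compound 2 `COc1ccc2c(Nc3ccc(F)cc3)c(C(=O)C(F)(F)F)c(=O)oc2c1` share one core and differ only in the aniline part. In a functional assay on MCF7 cells (Homo sapiens) for antiproliferative activity, read by MTT assay, with a stated time of 48 h (a lower number here means a stronger inhibitor, a higher number a weaker inhibitor), compound 1 gives 55700 nM, and compound 2 gives 9740 nM. The change between them, (fluoro in place of methoxy on an aromatic carbon), brings a 5.7-fold lower number from compound 1 to compound 2 (0.76 log units; beyond the scatter).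

Compound 3 `COc1ccc(Nc2c(C(=O)C(F)(F)F)c(=O)oc3ccc(OC)cc23)cc1` carries the same methoxy-bearing aniline on a core built from the same atoms joined differently; the difference between the two cores is not broken down here. In this assay compound 3 reaches only a limit, > 100000 nM, which is the limit of > 100000 nM in this assay, at which 1 of the 3 values shown sits.

Compound 4 `COc1ccc2oc(=O)c(C(=O)C(F)(F)F)c(Nc3ccc(F)cc3)c2c1` stands to compound 3 as compound 2 stands to compound 1: the change fluoro in place of methoxy on an aromatic carbon is the same change at the same place. Compound 4 is expected at an estimated 30000 nM, between 8000 nM and 120000 nM, because the earlier case gave a 5.7-fold lower number from compound 1 to compound 2 (0.76 log units; beyond the scatter). The expected step is an at least 3.3-fold lower number from compound 3 to compound 4 (0.52 log units; beyond the scatter), resting on that single earlier case. Since compound 3 showed only a limit, the outcome for compound 4 could itself again be a limit.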

Compound 4, half-maximal inhibitory concentration: > 100000 nM
Compound 4 was reported as a limit; the forecaster's own chance of this, stated with the estimate: 30%; middle value at least 3.3-fold (0.52 log units) away from the limit.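

In this assay compound 4 reaches only a limit, > 100000 nM. With compound 3 also reported only as a limit, no step can be read between compound 3 and compound 4: the limit of > 100000 nM in this assay, at which 2 of the 4 values shown sit.

From the compounds shown here alone, whether fluoro in place of methoxy lowers the number on the core of compound 3, as it did on the core of compound 1, remains open.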